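Swapping a Fluorophenyl Amide for a Furan Amide

The compounds below may be only part of what the source reports. "The series", "measured", "known", "first", "only" and "open" are said of these compounds alone.

Of the compounds shown here, three sharing one core have been tested in a functional assay on Ramos cells (Homo sapiens) for antiproliferative activity, read by CCK-8 assay, with a stated time of 72 h, tested at 40 uM; a higher number here means more inhibition at the concentration tested (going by the name of the read-out), a lower number less inhibition. Compound 1 `CN1CCN(c2ccc(Nc3nc(-c4cccc(NC(=O)c5ccc(C(F)(F)F)cc5)c4)sc3C(N)=O)cc2)CC1` gives 97.8%. Compound 2 `CN1CCN(c2ccc(Nc3nc(-c4cccc(NC(=O)c5ccc(F)cc5)c4)sc3C(N)=O)cc2)CC1` gives 95.9%, and compound 3 `CN1CCN(c2ccc(Nc3nc(-c4cccc(NC(=O)c5ccccc5F)c4)sc3C(N)=O)cc2)CC1` gives 95.5%. Compound 3 has the smallest of the three numbers, yet the gaps to it, a number 2.3 percentage points lower from compound 1 to compound 3 (within the scatter) and a number 0.4 percentage points lower from compound 2 to compound 3 (within the scatter), are both within the scatter, so the three compounds cannot be told apart on these data.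

Compound 4 `CN1CCN(c2ccc(Nc3nc(-c4cccc(NC(=O)c5ccco5)c4)sc3C(N)=O)cc2)CC1` has not yet been measured. It differs from compound 3 in one place: furan-2-yl in place of 2-fluorophenyl on a carbonyl carbon. The two measured steps that bear on this are the ring swaps at the same carbonyl carbon, a number 2.3 percentage points lower from compound 1 to compound 3 (within the scatter) and a number 0.4 percentage points lower from compound 2 to compound 3 (within the scatter), both small. On that basis no step beyond the scatter is expected in this assay. The estimated step of a number 2.5 percentage points lower from compound 3 to compound 4 (within the scatter) lies within the scatter. Compound 4 is therefore expected to give 93%, with a range from 80% to 99%.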

Compound 4, a percentage reported as inhibition, at one concentration (the size of the read-out at that concentration, not a potency): 96.7%
Compound 4: the middle estimate sits 3.7 percentage points below what was measured; the range from low to high includes it.
By their numbers in this assay, from the lowest: compounds 3, 2, 4 and 1 (each within the scatter of the next).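

Until now, every group on this carbonyl carbon was a substituted phenyl. Furan-2-yl brings a five-membered aromatic ring with one hetero atom and no fluorine, yet in this assay the swap gives only small steps (a number 1.2 percentage points higher from compound 3 to compound 4 (within the scatter)) and (a number 0.8 percentage points higher from compound 2 to compound 4 (within the scatter)) and (a number 1.1 percentage points lower from compound 1 to compound 4 (within the scatter)), so among these four compounds neither a six-membered ring nor fluorine is needed to keep the number this high. No measurement shown gives a reason for this.

On these data alone, what remains open is whether a group of a different kind on this carbonyl carbon, such as a short alkyl chain, a pyridine ring or a phenyl ring carrying a carboxylic acid, would keep the number this high. A reading at a single concentration also leaves open whether these four compounds differ in potency at lower concentrations.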